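This account rests on a few compounds, and the source may have more. Where it says the series, first, only, none or still open, it means among the compounds named here.

Measured in an in vivo ADME assay on the whole organism for pharmacokinetics, with Rattus norvegicus as the target, at a dose of 5 mg/kg; a higher number here means faster removal of the compound, a lower number slower removal:
- Compound 1 `Cc1ccc([C@H](C(=O)N(C)C)N2C(=O)[C@@H](C3Cc4ccccc4C3)NC(=O)[C@H]2CC(C)C)cn1`: 18 mL/min/kg
- Compound 2 `COc1ccc([C@H](C(=O)N2CCOCC2)N2C(=O)[C@@H](C3Cc4ccccc4C3)NC(=O)[C@H]2CC(C)C)cn1`: 35 mL/min/kg

Compound 2 stands within the scatter of compound 1, so these two values set no order. Compound 3 `COc1ccc([C@H](C(=O)N(C)C)N2C(=O)[C@@H](C3Cc4ccccc4C3)NC(=O)[C@H]2CC(C)C)cn1` differs from compound 2 as follows: dimethylamino in place of morpholin-4-yl on a carbonyl carbon. This places dimethylamino in place of morpholin-4-yl on a carbonyl carbon. Within the data shown here, no measured step isolates this change. Compound 1 also carries dimethylcarbamoyl and gives 18 mL/min/kg, so no step beyond the scatter is expected. The expected step is small and downward: a 1.3-fold lower number from compound 2 to compound 3 (0.13 log units; within the scatter). For compound 3 the estimated clearance is 26 mL/min/kg, with an expected range of 14 mL/min/kg to 45 mL/min/kg.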

Compound 3, clearance in the Rattus norvegicus assay: 23 mL/min/kg
Estimate against measurement, compound 3: 1.1-fold (0.05 log units) above; low and high end bracket the measured number.
By their numbers in the Rattus norvegicus assay, from the lowest: compounds 1, 3 and 2 (each within the scatter of the next).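

In the Rattus norvegicus assay, compound 2 gives 35 mL/min/kg, compound 3 gives 23 mL/min/kg and compound 1 gives 18 mL/min/kg; dimethylamino in place of morpholin-4-yl on a carbonyl carbon can now be read directly (a 1.5-fold lower number from compound 2 to compound 3 (0.18 log units; within the scatter)), and methoxy in place of methyl on an aromatic carbon also gives a reading (a 1.3-fold higher number from compound 1 to compound 3 (0.11 log units; within the scatter)), so neither change separates its pair. In a physicochemical assay for lipophilicity, read by HPLC (a lower number here means a more polar compound, a higher number a more lipophilic compound), compound 2 gives 2.7 and compound 3 gives 2.7, and the carbonyl change gives the same picture (no change at the digits printed from compound 2 to compound 3 (within the scatter)). No available evidence bears on these readings.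

Still open, as far as these compounds go, is whether a carboxylic acid or a longer chain on the carbonyl carbon would separate from compound 3 in the Rattus norvegicus assay. The same holds for chlorine on the aromatic carbon.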